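The compounds below may be only part of what the source reports. "The series", "measured", "known", "first", "only" and "open" are said of these compounds alone.

Working notes on the series. The shared core carries, at one end, a pyridyl-bearing ring system and, at the other, a substituted amino side chain. Compound 1 `CNc1nc(NCc2ccc(NC(C)=O)cc2)cc(-c2ccccn2)n1` and compound 2 `CNc1nc(NCc2ccc(N(C)C(C)=O)cc2)cc(-c2ccccn2)n1` differ only in methyl in place of hydrogen on an amide-type nitrogen; compound 3 `CNc1nc(NCC2CC2)cc(-c2ccccn2)n1` carries a cyclopropylmethyl side chain instead. The difference between the core of compound 1 and that of compound 3 is not broken down here.

In a functional assay on HEK293 cells for agonist activity at G-protein coupled receptor 39 (Homo sapiens), read by inositol phosphate accumulation (a higher number here means that more compound is needed for the effect, a lower number that less compound is needed), compound 1 gives 5 nM. Compound 2 gives 1180 nM; the step is a 240-fold higher number from compound 1 to compound 2 (2.37 log units; beyond the scatter). Compound 3 gives 164 nM, which stands between the other two.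

Compound 4 `CN(C)c1nc(NCC2CC2)cc(-c2ccccn2)n1` is compound 3 with methyl in place of hydrogen on a nitrogen on an aromatic ring. This is the same kind of change as from compound 1 to compound 2, but not the same one: there the place was an amide-type nitrogen whose other neighbours are an aromatic carbon and a carbonyl carbon; here it is a nitrogen on an aromatic ring whose other neighbours are an aromatic carbon and a saturated chain carbon. In both cases a hydrogen on a nitrogen is replaced by methyl.

For the measured compounds named here, only the one earlier example of this kind of change exists, and it sits on a different nitrogen. That earlier step was a 240-fold higher number from compound 1 to compound 2 (2.37 log units; beyond the scatter). The step from compound 3 to compound 4 is expected to be a loss but a smaller one, estimated at a 9.1-fold higher number from compound 3 to compound 4 (0.96 log units; beyond the scatter). For compound 4 in this assay the expected value is 1500 nM, with a range from 300 nM to 8000 nM.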

Compound 4, half-maximal effective concentration: > 25000 nM
Compound 4 gave a limit, no number; the forecaster's own chance of this, stated with the estimate: 15%; middle value at least 16-fold (1.22 log units) away from the limit.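

In this assay compound 4 gives > 25000 nM, which is a limit of the assay and not a number. Methyl in place of hydrogen on a nitrogen goes with a large loss in both available pairs, a 240-fold higher number from compound 1 to compound 2 (2.37 log units; beyond the scatter) on the amide-type nitrogen and an at least 150-fold higher number from compound 3 to compound 4 (2.18 log units; beyond the scatter) on the nitrogen on an aromatic ring, so the loss is not confined to one core among the compounds shown, although two pairs on two different nitrogens make no general rule for the series, and how closely the two steps agree stays unsettled: the same change on two cores in this assay, a 240-fold higher number (2.37 log units; beyond the scatter) from compound 1 to compound 2 and an at least 150-fold higher number (2.18 log units; beyond the scatter) from compound 3 to compound 4; the limit leaves it open whether they differ. The true size of the second step is likewise not shown, since only its lower bound can be read, and the limit is reached by one compound of those shown: the limit of > 25000 nM in this assay, at which 1 of the 4 values shown sits.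

Open, from the compounds shown here alone, is how the methylamino group compares with a plain amino group or with ethylamino on the core of compound 3, which would show whether the hydrogen on that nitrogen or the size of the group there tracks with the number. Also open, going by these compounds, is how dimethylamino behaves with the side chain of compound 1, where the starting value of 5 nM lies far lower.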